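Aryl swap on the shared core: compound 2 to compound 3

The source may report more compounds than this note shows. Statements on the series, on what has been measured and on what is new or still open speak of the compounds shown alone.

Measured compounds:
compound 1 `CCOC(=O)c1c(-c2ccccc2OC)c(C#N)c(=O)n(/N=C(\C)c2ccc(NS(=O)(=O)c3ccc(Cl)cc3)cc2)c1N` — 11400 nM
compound 2 `CCOC(=O)c1c(-c2ccccc2Cl)c(C#N)c(=O)n(/N=C(\C)c2ccc(NS(=O)(=O)c3ccc(Cl)cc3)cc2)c1N` — 11400 nM

In a functional assay on HepG2 cells (Homo sapiens) for cytotoxicity, read by sulforhodamine B assay, with a stated time of 48 h (a lower number here means a stronger inhibitor, a higher number a weaker inhibitor), compound 2 gives 11400 nM and stands level with compound 1, since the step of no change at the digits printed from compound 1 to compound 2 (within the scatter) lies within the scatter. Compound 3 `CCOC(=O)c1c(-c2ccc(N(C)C)cc2)c(C#N)c(=O)n(/N=C(\C)c2ccc(NS(=O)(=O)c3ccc(Cl)cc3)cc2)c1N` is the next step, with 4-(dimethylamino)phenyl in place of 2-chlorophenyl on an aromatic carbon. Going by the values given here, only the step from compound 1 to compound 2 bears on this change, and it showed nothing beyond the scatter, so compound 3 is expected to sit near compound 2, with a step of a 1.1-fold lower number from compound 2 to compound 3 (0.06 log units; within the scatter). The value of compound 3 is estimated at 10000 nM, within 3000 nM to 40000 nM.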

Compound 3, half-maximal inhibitory concentration: 21000 nM
The estimate for compound 3 lay 2.1-fold (0.32 log units) below the measured number, and the stated range covers the measured number.
By their numbers in this assay, from the lowest: compounds 1, 2 and 3 (each within the scatter of the next).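

Replacing the aryl group at this position with 4-(dimethylamino)phenyl gives a 1.8-fold higher number from compound 2 to compound 3 (0.27 log units; within the scatter) in this assay, and against 2-methoxyphenyl it gives a 1.8-fold higher number from compound 1 to compound 3 (0.27 log units; within the scatter). The earlier compounds shown here compared only 2-chlorophenyl with 2-methoxyphenyl, whereas these steps show that a phenyl group carrying a dimethylamino group, named at its 4-position, also stays within the scatter.

From the compounds shown here alone, whether a phenyl group carrying a carboxylic acid or a longer alkyl chain would move the number beyond the scatter remains open. Nothing available explains why these changes leave the number within the scatter.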